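Stepwise Demethylation of a Dihydrochalcone Cytotoxicity Series

The source may report more compounds than this note shows. Statements on the series, on what has been measured and on what is new or still open speak of the compounds shown alone.

This account follows a small set of dihydrochalcone-type compounds tested in a functional assay on cells (Mus musculus) for cytotoxicity, read by MTT assay, with a stated time of 72 h; on this read-out higher numbers stand for weaker inhibition and lower numbers for stronger inhibition. Compound 1, `COc1ccc(CCC(=O)c2ccc(O)cc2)c(OC)c1`, gives 32200 nM in this assay. Compound 2, `COc1ccc(CCC(=O)c2ccc(O)cc2)c(O)c1`, gives 81400 nM in this assay. Within the data shown here, the single measured step, a 2.5-fold higher number from compound 1 to compound 2 (0.40 log units; beyond the scatter), arises from a hydrogen in place of methyl on an oxygen on an aromatic ring. Compound 2 therefore stands at the highest of the two numbers shown, with compound 1 as its nearest neighbour at a lower number beyond the scatter.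

Compound 3, `O=C(CCc1ccc(O)cc1O)c1ccc(O)cc1`, has not yet been measured in this assay. It differs from compound 2 by hydrogen in place of methyl on an oxygen on an aromatic ring. Among the measured compounds shown here, the only step that bears on this change is the step from compound 1 to compound 2, which shows the same replacement at a neighbouring position and gave a modest rise in the number. On that basis a step of similar size and direction is expected, so that compound 3 is estimated at 160000 nM, with a range from 60000 nM to 400000 nM. The expected step is a 2.0-fold higher number from compound 2 to compound 3 (0.29 log units; within the scatter). A result reported only as a limit cannot be ruled out at these concentrations.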

Compound 3, half-maximal inhibitory concentration: > 100000 nM
Compound 3: no number, only a limit (the forecaster's own chance of this, stated with the estimate: 30%); the middle value lies beyond the limit too.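

In this assay the entry for compound 3, > 100000 nM, is a limit of the assay and not a number. Methoxy to hydroxy at this second oxygen on an aromatic ring can be read only from its floor, as an at least 1.2-fold higher number from compound 2 to compound 3 (0.08 log units; that floor lies within the scatter), so the result fixes the direction of the change as far as that floor goes but not its size, and it cannot settle whether this step matches the earlier one, a 2.5-fold higher number from compound 1 to compound 2 (0.40 log units; beyond the scatter). What the earlier compounds did not show is that the replacement, made at this oxygen too, gives no lower number and yields an entry that is no longer a number at all, and compound 3 alone among the compounds shown has an entry of this kind: the limit of > 100000 nM in this assay, at which 1 of the 3 values shown sits.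

The compounds shown carry only methyl or hydrogen on these oxygens, so it remains open what a longer chain such as ethyl, or an amine in place of the oxygen, would give in this assay. From the compounds shown here alone, all three also keep the same carbonyl and the same hydroxy group on the other ring, and what a carboxylic acid at either place would do remains unknown.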